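Adding a Second Chloro Group to Compound 3

The source may report more compounds than this note shows. Statements on the series, on what has been measured and on what is new or still open speak of the compounds shown alone.

Of the compounds shown here, three sharing one core have been measured in a functional assay on PC-12 cells (Rattus norvegicus) for cytotoxicity, read by MTT assay, with stated times of 3 h and 2 h, tested at 20 uM; on this read-out lower numbers stand for a weaker effect and higher numbers for a stronger effect at the one concentration tested. Compound 1 `CCOC(=O)c1cc2ccc(OCCCn3cc(CNC(=O)CCCCC4CCSS4)nn3)cc2oc1=O` gives 42.1%. Compound 2 `O=C(CCCCC1CCSS1)NCc1cn(CCCOc2ccc3cc(C(=O)O)c(=O)oc3c2)nn1` gives 66.8% in this assay. Compound 3 `O=C(CCCCC1CCSS1)NCc1cn(CCCOc2ccc3cc(-c4ccc(Cl)cc4)c(=O)oc3c2)nn1` gives 75.6% in this assay, the highest of the three numbers, though its gap to compound 2 lies within the scatter, so no order between those two can be claimed. The measured steps were a number 24.7 percentage points higher from compound 1 to compound 2 (beyond the scatter) and a number 33.5 percentage points higher from compound 1 to compound 3 (beyond the scatter), both beyond the scatter, while a number 8.8 percentage points higher from compound 2 to compound 3 (within the scatter), within it.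

Compound 4 `O=C(CCCCC1CCSS1)NCc1cn(CCCOc2ccc3cc(-c4ccc(Cl)c(Cl)c4)c(=O)oc3c2)nn1` is not yet measured. It differs from compound 3 by chloro in place of hydrogen on an aromatic carbon. Among the compounds with values here, none of the measured steps adds a chloro group to a six-membered aromatic ring of carbon only that already carries one; the nearest step, a number 8.8 percentage points higher from compound 2 to compound 3 (within the scatter), brought the 4-chlorophenyl group in and stayed within the scatter. With nothing pointing to a direction, the expected step is a number 1.4 percentage points higher from compound 3 to compound 4 (within the scatter), none beyond the scatter. The estimate for compound 4 in this assay is 77%, with a range from 62% to 90%.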

Compound 4, a percentage reported as activity, at one concentration (the size of the read-out at that concentration, not a potency): 51.2%
Estimate against measurement, compound 4: 25.8 percentage points above; the measured number lies below the stated range.
By their numbers in this assay, from the lowest: compounds 1 and 4 (each within the scatter of the next); then compounds 2 and 3 (each within the scatter of the next).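

On the 4-chlorophenyl group, a carbon ortho to the chloro group proves sensitive: in this assay one added chloro atom brings a number 24.4 percentage points lower from compound 3 to compound 4 (beyond the scatter) and so changes the result as much as swapping a whole group did earlier. The new 3,4-dichlorophenyl group also gives a number 15.6 percentage points lower from compound 2 to compound 4 (beyond the scatter) when it replaces carboxy, but a number 9.1 percentage points higher from compound 1 to compound 4 (within the scatter) when it replaces ethoxycarbonyl, so compound 4 cannot be told apart from compound 1 in this read-out. No measurement available here accounts for the effect of the second chloro group.

On these data alone, whether this fall belongs to chloro itself remains open, since a fluoro, methyl or methoxy group at the same place could behave differently. An unsubstituted phenyl group would also show what the first chloro group contributes.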